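The source may report more compounds than this note shows. Statements on the series, on what has been measured and on what is new or still open speak of the compounds shown alone.

Measured so far in a functional assay (HSMC cells, Homo sapiens) for antiproliferative activity, with a stated time of 72 h; a higher number here means a weaker inhibitor, a lower number a stronger inhibitor:
Compound 1 `COC(=O)[C@H](CCSC)NC(=O)c1ccc(OC[C@@H]2COc3ccccc3O2)cc1-c1ccccc1C`: 193000 nM
Compound 2 `COC(=O)CNC(=O)c1ccc(OC[C@H]2COc3ccccc3O2)cc1-c1ccccc1C`: 27000 nM
Compound 3 `COC(=O)CNC(=O)c1ccc(OC[C@@H]2COc3ccccc3O2)cc1-c1ccccc1C`: 700 nM

Compound 3 has the lowest number of the three, and its steps to both others lie beyond the scatter. Compound 4 `COC(=O)CNC(=O)c1ccc(OC[C@@H]2COc3ccccc3O2)cc1-c1ccccc1OC` differs from it in a single group: methoxy in place of methyl on an aromatic carbon. This is methoxy in place of methyl on an aromatic carbon, ortho to a large group, turning 2-methylphenyl into 2-methoxyphenyl.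

Neither measured step changes this group. The large 39-fold lower number from compound 2 to compound 3 (1.59 log units; beyond the scatter) reflects (the fact that compounds 2 and 3 differ only in the configuration as drawn), while the equally large a 280-fold lower number from compound 1 to compound 3 (2.44 log units; beyond the scatter) comes from hydrogen in place of 2-(methylsulfanyl)ethyl. Compound 4 keeps both of the features that these steps favour, so neither step predicts a large change here. With compound 3 at the low end at 700 nM, a small rise in this assay is expected, probably not far beyond the scatter, though the direction is uncertain. The expected change is a 1.4-fold higher number from compound 3 to compound 4 (0.15 log units; within the scatter). For compound 4 the estimated value is 1000 nM, with an expected range of 300 nM to 3500 nM.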

Compound 4, half-maximal inhibitory concentration: 35000 nM
Compound 4: the middle estimate sits 35-fold (1.54 log units) below what was measured; the whole stated range lies below it.
By their numbers in this assay, from the lowest: compound 3; then compounds 2 and 4 (each within the scatter of the next); then compound 1.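

In this assay, for the compounds shown here, the first change at this position is far from neutral: a 50-fold higher number from compound 3 to compound 4 (1.70 log units; beyond the scatter). The earlier steps shown here touched only the 2-(methylsulfanyl)ethyl side chain and the configuration at the saturated ring carbon, whereas this one shows that replacing methyl with methoxy on an aromatic carbon, ortho to a large group, can by itself give a large step, of the same class as a 39-fold lower number from compound 2 to compound 3 (1.59 log units; beyond the scatter). Nothing in the information available explains this step.

The compounds shown leave open whether hydrogen, chlorine, ethyl or hydroxyl at this place would stay close to compound 3 or move as far as methoxy does. They also leave open whether the 2-methoxyphenyl group would have the same effect alongside the S configuration or the 2-(methylsulfanyl)ethyl side chain.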